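Indane for Tolyl: A Small Step Put to the Test

The source may hold more compounds than are shown below. What is called first, only, known or untested is meant among the compounds shown, and "the series" means these compounds.

The series shares one core, carried in compound 2 `Cc1cccc(OC2CCN(c3ccc(-n4ccnc4)nn3)CC2)c1`, compound 1 `FC(F)(F)c1ccc(OC2CCN(c3ccc(-n4ccnc4)nn3)CC2)cc1` and compound 3 `CC(C)(C)c1nnc(-c2ccc(N3CCC(Oc4ccccc4C(F)(F)F)CC3)nn2)o1`. In an assay on microsomes from liver for inhibition of acyl-CoA desaturase 1 (Rattus norvegicus) (a lower number here means a stronger inhibitor, a higher number a weaker inhibitor), compound 2 gives 251 nM. In this assay compound 1 gives 371 nM, a number that sits within the usual scatter of the number for compound 2, so the two cannot be told apart. In this assay compound 3 gives 980 nM, which lies beyond the scatter and higher than compound 2; the difference in structure between those two, however, touches more than one place, so only the two values themselves can be compared.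

The unmeasured compound 4 `c1cc2c(c(OC3CCN(c4ccc(-n5ccnc5)nn4)CC3)c1)CCC2` changes compound 2 at one place: 2,3-dihydro-1H-inden-4-yl in place of 3-methylphenyl on an oxygen on a saturated carbon. For the measured compounds named here, no measured pair in this set differs at just that place, so no measured step exists to lean on. The shown compounds give no reason to expect a large step in this assay in either direction, and the estimated step from compound 2 to compound 4 is a 1.1-fold lower number from compound 2 to compound 4 (0.06 log units; within the scatter), which is expected to stay within the scatter. Compound 4 is therefore expected to give 220 nM in this assay, with a range from 80 nM to 600 nM.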

Compound 4, half-maximal inhibitory concentration: 10 nM
For compound 4 the middle estimate is 22-fold (1.34 log units) above the measured one; the whole stated range lies above it.
By their numbers in this assay, from the lowest: compound 4; then compounds 2 and 1 (each within the scatter of the next); then compound 3.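

In this assay, the group on the oxygen on a saturated carbon turns out to be far from a silent place: 2,3-dihydro-1H-inden-4-yl in place of 3-methylphenyl gives a 25-fold lower number from compound 2 to compound 4 (1.40 log units; beyond the scatter) and marks a large change, although the entering group keeps the six-membered aromatic ring of carbon only, adds a five-membered non-aromatic ring of carbon only, and has no hydrogen-bond donors or acceptors and no net charge. For the compounds shown here, the earlier compounds offered no measured step at this place, so this pair is the first direct sign of how strongly the number can respond to the group carried there. Nothing in the data shown bears on what lies behind a step of this size.

A single pair leaves open whether the closed five-membered ring itself matters or whether open groups on the same oxygen, such as 3-ethylphenyl or 3-isopropylphenyl, would give a similar number. It also leaves open whether 2,3-dihydro-1H-inden-4-yl would bring a comparable step on the core of compound 3, which carries a tert-butyl oxadiazole in place of the imidazole.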